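Trading thiophen-2-yl for furan-2-yl on a weak compound

A few compounds are considered here, and "the series" means these few. Any claim that something is new, unique, unknown or untested is made for them only; others in the source may bear on it.

Within the data shown here, only two compounds have numbers so far in a functional assay on HL-60 cells (Homo sapiens) for cytotoxicity, read by ELISA, with a stated time of 2 days; a lower number here means a stronger inhibitor, a higher number a weaker inhibitor. Compound 1 `Oc1ccc(-c2cc(-c3ccccc3)cc(-c3ccccc3)n2)cc1` gives 1400 nM. Compound 2 `Oc1cccc(-c2cc(-c3ccccc3)nc(-c3cccs3)c2)c1` gives 18900 nM, the higher of the two numbers, and its gap to compound 1 lies beyond the scatter, so compound 2 is the weaker inhibitor of this pair.

Compound 3 `Oc1cccc(-c2cc(-c3ccccc3)nc(-c3ccco3)c2)c1` has furan-2-yl in place of thiophen-2-yl on an aromatic carbon, next to the ring nitrogen (furan-2-yl in place of thiophen-2-yl on an aromatic carbon). Among the measured compounds shown here, both groups are five-membered aromatic rings with 1 hetero atom, and no measured pair yet shows what such an exchange does. The closest measured relative is compound 2 at 18900 nM, so no step beyond the scatter, in either direction, is expected in this assay. The estimated change is a 1.3-fold lower number from compound 2 to compound 3 (0.10 log units; within the scatter). For compound 3 the expected value is 15000 nM, within an estimated range of 6000 nM to 40000 nM.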

Compound 3, half-maximal inhibitory concentration: 24000 nM
For compound 3 the middle estimate is 1.6-fold (0.20 log units) below the measured one, and the stated range covers the measured number.
By their numbers in this assay, from the lowest: compound 1; then compounds 2 and 3 (each within the scatter of the next).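

In this assay, putting furan-2-yl in place of thiophen-2-yl on this aromatic carbon, next to the ring nitrogen, gives a 1.3-fold higher number from compound 2 to compound 3 (0.10 log units; within the scatter) and so leaves the two compounds indistinguishable. Among these compounds, this is the first measured pair at this position, and it shows that, for this one pair, exchanging the sulfur of the five-membered aromatic ring for oxygen produces no readable step. Among the compounds shown here, nothing measured so far bears on the reason for this outcome.

As far as these compounds go, whether a group of a different kind here, such as an amine or a carboxylic acid, would move the number remains open. Compound 1 differs from compound 2 in more than one place, so the compounds shown do not tie its lower number to any single change.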